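The source may report more compounds than this note shows. Statements on the series, on what has been measured and on what is new or still open speak of the compounds shown alone.

Measured compounds:
- compound 1 `Oc1cccc(NCCN2CCN(c3ccccc3)CC2)c1` gives 252 nM
- compound 2 `Cc1cccc(N(C)CCCN2CCN(c3ccccc3)CC2)c1` gives 84.8 nM

In an assay on HEK293 cells for displacement of a labelled ligand from 5-hydroxytryptamine receptor 7 (Homo sapiens), read by scintillation counting, with a stated time of 30 min (on this read-out higher numbers stand for weaker inhibition and lower numbers for stronger inhibition), compound 2 has the lower of the two numbers; its nearest neighbour is compound 1, whose number is higher by a margin that lies beyond the scatter. The step to compound 3 `CN(CCCN1CCN(c2ccccc2)CC1)c1cccc(Cl)c1` is a single swap on the aryl group attached to the methylated nitrogen: chloro in place of methyl on an aromatic carbon, so that a 3-methylphenyl becomes a 3-chlorophenyl while the rest of the structure is unchanged. For the measured compounds named here, no measured pair in this set shows the same swap, so there is no directly comparable step to lean on. In this assay this author expects an exchange of one small substituent for another of the same size, at the same ring position, to move the number little, in either direction, and not beyond the scatter. The estimate for compound 3 is therefore 70 nM (range 25 nM to 200 nM), a step of a 1.2-fold lower number from compound 2 to compound 3 (0.08 log units; within the scatter).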

Compound 3, inhibition constant: 179 nM
For compound 3 the middle estimate is 2.6-fold (0.41 log units) below the measured one, within the range that was stated.
By their numbers in this assay, from the lowest: compound 2; then compounds 3 and 1 (each within the scatter of the next).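

In this assay the change from 3-methylphenyl to 3-chlorophenyl gives a 2.1-fold higher number from compound 2 to compound 3 (0.32 log units; beyond the scatter), so this position, meta to a large group, does not treat the two substituents alike, although each brings one heavy atom and neither brings a hydrogen-bond donor or acceptor. For the compounds shown here, the earlier compounds differ in more than one place, so this is the first single-change reading at this ring position, and the step is modest. Nothing measured here explains the difference.

The compounds shown leave open whether a fluoro, a methoxy or a trifluoromethyl group at this position would give a number nearer that of the methyl or the chloro compound. They also leave open whether the same swap would give a similar step with a shorter chain or with the amine hydrogen in place of the nitrogen's methyl.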